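Swapping the Amide Aryl Group: Chloro to Acetyl

The source may hold more compounds than are shown below. What is called first, only, known or untested is meant among the compounds shown, and "the series" means these compounds.

Of the compounds shown here, three built on one shared core have been tested in a functional assay on CHO cells for antagonist activity at Orexin/Hypocretin receptor type 1 (Homo sapiens), read by FLIPR and calcium flux; a lower number here means a stronger inhibitor, a higher number a weaker inhibitor. Compound 1 `Cc1cccc(NC(=O)CSc2nnc(-c3ccoc3C)n2Cc2ccco2)c1C` gives only a limit, > 15800 nM (the limit of > 15800 nM in this assay, at which 1 of the 3 values shown sits). In this assay compound 2 `Cc1cccc(NC(=O)CSc2nnc(-c3ccoc3C)n2Cc2ccco2)c1` gives 2510 nM, and compound 3 `Cc1occc1-c1nnc(SCC(=O)Nc2cccc(Cl)c2)n1Cc1ccco1` gives 2000 nM. Compound 3 thus has the lowest of the two plain numbers, but its gap to compound 2 lies within the scatter: a 1.3-fold lower number from compound 2 to compound 3 (0.10 log units; within the scatter). The larger steps are an at least 6.2-fold lower number from compound 1 to compound 2 (0.79 log units; beyond the scatter) and an at least 7.9-fold lower number from compound 1 to compound 3 (0.89 log units; beyond the scatter), both of which moved away from the limit.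

The next compound, compound 4 `CC(=O)c1ccc(NC(=O)CSc2nnc(-c3ccoc3C)n2Cc2ccco2)cc1`, changes the aryl group on the amide nitrogen once more: 4-acetylphenyl in place of 3-chlorophenyl on an amide-type nitrogen. Among the measured compounds shown here, no measured step matches this change directly. The step of a 1.3-fold lower number from compound 2 to compound 3 (0.10 log units; within the scatter) shows that exchanging chloro for methyl on that ring stayed within the scatter, whereas the step of an at least 6.2-fold lower number from compound 1 to compound 2 (0.79 log units; beyond the scatter) shows that removing one methyl brought the number down from the limit. An acetyl group at a new position is therefore hard to place from these data alone. For compound 4 a modest weakening is expected, a 2.5-fold higher number from compound 3 to compound 4 (0.40 log units; beyond the scatter). Compound 4 is estimated at 5000 nM, within a range from 1500 nM to 20000 nM.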

Compound 4, inhibition constant: 2510 nM
Beside the measured number, compound 4's estimate is 2.0-fold (0.30 log units) above it; measured number inside the range.
By their numbers in this assay, from the lowest: compounds 3, 2 and 4 (each within the scatter of the next). At a limit, above all of these: compound 1.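

In this assay, 4-acetylphenyl on the amide-type nitrogen brings in a carbonyl and a hydrogen-bond acceptor that 3-chlorophenyl lacks, yet the comparison gives a 1.3-fold higher number from compound 3 to compound 4 (0.10 log units; within the scatter), and against 3-methylphenyl it gives no change at the digits printed from compound 2 to compound 4 (within the scatter). Among the compounds shown here, until now this ring had carried only methyl or chloro, so the result shows that a clearly different group can sit here without a shift beyond the scatter, while 2,3-dimethylphenyl remains the one group that stands apart, with an at least 6.2-fold lower number from compound 1 to compound 4 (0.79 log units; beyond the scatter). That last step is only a minimum, since compound 1 gives a limit and not a plain number: the limit of > 15800 nM in this assay, at which 1 of the 4 values shown sits.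

Going by these compounds, whether the result for 4-acetylphenyl reflects the acetyl group itself or where it sits on the ring stays open, as does whether an amine, a carboxylic acid or a longer chain on the same ring would move the number beyond the scatter. The compounds shown also do not tell what would bring the number clearly lower than the level shared by compounds 2, 3 and 4.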